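A few compounds are considered here, and "the series" means these few. Any claim that something is new, unique, unknown or untested is made for them only; others in the source may bear on it.

Measured compounds:
compound 1 `CN1C(=O)C(C2CC2)N(C)c2nc(Nc3ccc(S(N)(=O)=O)cc3)ncc21` — 136 nM
compound 2 `CN1C(=O)C(c2ccccc2F)N(C)c2nc(Nc3ccc(S(N)(=O)=O)cc3)ncc21` — 75 nM
compound 3 `CN1C(=O)C(c2c(F)cccc2F)N(C)c2nc(Nc3ccc(S(N)(=O)=O)cc3)ncc21` — 42 nM

In an assay on Sf9 cells for inhibition of serine/threonine-protein kinase 4 (Homo sapiens), read by luminescence and ADP-Glo, with a stated time of 1 h, in the presence of a further agent that is not named here (a higher number here means a weaker inhibitor, a lower number a stronger inhibitor), compound 3 gives the lowest number of the three. Its nearest neighbour is compound 2, with a 1.8-fold lower number from compound 2 to compound 3 (0.25 log units; within the scatter); the furthest is compound 1, with a 3.2-fold lower number from compound 1 to compound 3 (0.51 log units; beyond the scatter), while a 1.8-fold lower number from compound 1 to compound 2 (0.26 log units; within the scatter) lies in between. Compound 4 `CN1C(=O)C(c2c(F)cccc2F)N(C)c2nc(Nc3ccc(S(=O)(=O)N(C)C)cc3)ncc21` keeps the core of compound 3 and differs only in one place: dimethylamino in place of amino on a sulfonyl sulfur. Going by the values given here, none of the measured steps touches the sulfonyl sulfur; all three alter the group on the saturated ring carbon. Among the compounds with values here, no measured step therefore bears on this change, and its size and direction in this assay are open. With that reservation, compound 4 is expected to give 90 nM (range 25 nM to 350 nM), meaning an estimated 2.1-fold higher number from compound 3 to compound 4 (0.33 log units; beyond the scatter).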

Compound 4, half-maximal inhibitory concentration: 181 nM
Compound 4: the middle estimate sits 2.0-fold (0.30 log units) below what was measured; the measured number falls inside the stated range.
By their numbers in this assay, from the lowest: compounds 3, 2, 1 and 4 (each within the scatter of the next, the first and the last beyond it).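

In this assay, dimethylamino in place of amino on a sulfonyl sulfur gives a 4.3-fold higher number from compound 3 to compound 4 (0.63 log units; beyond the scatter) and shows that this place responds to substitution, in the direction of a weaker inhibitor. Going by these compounds alone, the earlier steps all altered the group on the saturated ring carbon, so this is the first reading at the sulfonyl sulfur. Nothing available accounts for this step.

Going by these compounds, whether methylamino or morpholine on the sulfonyl sulfur would stand nearer to compound 3 or to compound 4 remains open. Also open, on these data alone, is whether the same change would give a similar step with cyclopropyl on the saturated ring carbon.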